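Replacing Pyridinyloxy with Hydroxymethyl on a Shared Core

The source may hold more compounds than are shown below. What is called first, only, known or untested is meant among the compounds shown, and "the series" means these compounds.

Measured so far in an ADME assay on MT2 cells (Homo sapiens) for cytotoxicity, read by MTT assay; on this read-out higher numbers stand for lower toxicity in this test and lower numbers for higher toxicity in this test:
- compound 1, `CSCc1ccc(Nc2ncc(Cc3c(F)cccc3F)o2)cc1`: > 100000 nM
- compound 2, `COCc1ccc(Nc2ncc(Cc3c(F)cccc3F)o2)cc1`: 32000 nM
- compound 3, `Fc1cccc(F)c1Cc1cnc(Nc2ccc(Oc3ccncc3)cc2)o1`: 21000 nM

The value of compound 1 is a limit of this assay, not a number; the limit of > 100000 nM in this assay, at which 1 of the 3 values shown sits, marks it. Compound 3 and compound 2 lie within the scatter of each other, a 1.5-fold lower number from compound 2 to compound 3 (0.18 log units; within the scatter), so neither can be called the more or less toxic of the two. From compound 1 the step to compound 3 was an at least 4.7-fold lower number from compound 1 to compound 3 (0.67 log units; beyond the scatter), and to compound 2 it was an at least 3.1-fold lower number from compound 1 to compound 2 (0.49 log units; beyond the scatter).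

Compound 4, `OCc1ccc(Nc2ncc(Cc3c(F)cccc3F)o2)cc1`, is not yet measured. Relative to compound 3 the change is hydroxymethyl in place of (pyridin-4-yl)oxy on an aromatic carbon. The group that enters is a short two-atom chain on the ring, closer in shape to the methoxymethyl of compound 2 than to the ring-bearing group of compound 3. Among the compounds with values here, the steps that bear on it are a 1.5-fold lower number from compound 2 to compound 3 (0.18 log units; within the scatter), small and within scatter, and an at least 3.1-fold lower number from compound 1 to compound 2 (0.49 log units; beyond the scatter), which shows that a small chain at this position can push the number upward.

The expected step is therefore a modest rise, a 1.9-fold higher number from compound 3 to compound 4 (0.28 log units; within the scatter), toward the region of compound 2 and compound 1. Compound 4 is estimated at 40000 nM, with a range from 15000 nM to 120000 nM.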

Compound 4, half-maximal cytotoxic concentration: > 100000 nM
Compound 4 gave a limit, no number (the forecaster's own chance of this, stated with the estimate: 25%); at least 2.5-fold (0.39 log units) between middle value and limit.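

In this assay the swap of (pyridin-4-yl)oxy for hydroxymethyl gave an at least 4.7-fold higher number from compound 3 to compound 4 (0.67 log units; beyond the scatter) and so moved the reading toward lower toxicity in this test, which shows that this position responds to the change even though compound 2 and compound 3 had stayed within the scatter of each other. The removal of one methyl from the oxygen of the chain gave an at least 3.1-fold higher number from compound 2 to compound 4 (0.49 log units; beyond the scatter) on the same shared core, so a short chain at this place does not fix the reading by its length alone, and the free hydroxy end of compound 4 separates it from the methoxymethyl of compound 2. Compound 1 and compound 4 both stand at a limit rather than at a number, so the step between them cannot be read and the methylsulfanyl and hydroxy ends cannot be ranked against each other: the limit of > 100000 nM in this assay, at which 2 of the 4 values shown sit.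

The compounds shown leave open whether an amine or a carboxylic acid in place of the hydroxy would stay at this limit or bring the reading back into the measurable range. They also leave open whether a longer chain such as hydroxyethyl would keep the reading of compound 4 or fall back toward that of compound 2.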